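A few compounds are considered here, and "the series" means these few. Any claim that something is new, unique, unknown or untested is made for them only; others in the source may bear on it.

In a functional assay on U-251 cells (Homo sapiens) for antiproliferative activity, read by MTT assay, with a stated time of 72 h (on this read-out higher numbers stand for weaker inhibition and lower numbers for stronger inhibition), compound 1 `O=C(Nc1ccc(Cl)c(-c2nnc3c(Cl)cccn23)c1)c1ccc(C(F)(F)F)cc1Cl` gives only a limit, > 100000 nM. Compound 2 `O=C(Nc1ccc(Cl)c(-c2nnc3c(Cl)cccn23)c1)c1ccc(F)cc1Cl` likewise gives only a limit, > 100000 nM. Within the data shown here, compound 3 `O=C(Nc1ccc(Cl)c(-c2nnc3c(Cl)cccn23)c1)c1cccc(Cl)c1` gives 43100 nM, the only actual number among the three, and this makes compound 3 the reference point. the limit of > 100000 nM in this assay, at which 2 of the 3 values shown sit, marks where compound 1 and compound 2 sit. Among the measured compounds shown here, the step that the two limits leave unreadable from compound 1 to compound 2 cannot be read, while an at least 2.3-fold lower number from compound 2 to compound 3 (0.36 log units; beyond the scatter) is the one measured change at the carbonyl carbon. Compound 4 `O=C(Nc1ccc(Cl)c(-c2nnc3c(Cl)cccn23)c1)c1cccnc1Cl` differs from compound 3 by 2-chloropyridin-3-yl in place of 3-chlorophenyl on a carbonyl carbon. For the measured compounds named here, no measured step swaps a ring carbon for a nitrogen, so the expectation for compound 4 in this assay leans on compound 3 alone and is estimated at 55000 nM, spanning 18000 nM to 150000 nM, a step of a 1.3-fold higher number from compound 3 to compound 4 (0.11 log units; within the scatter) that is expected to stay within the scatter.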

Compound 4, half-maximal inhibitory concentration: > 100000 nM
Compound 4: no number, only a limit; the forecaster's own chance of this, stated with the estimate: 35%; middle value at least 1.8-fold (0.25 log units) from the limit.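

In this assay, this position on the carbonyl carbon tolerates little: putting 2-chloropyridin-3-yl in place of 3-chlorophenyl gives an at least 2.3-fold higher number from compound 3 to compound 4 (0.36 log units; beyond the scatter). Among these compounds, compound 4 reaches only a limit, so compound 3 remains the only one with an actual number: the limit of > 100000 nM in this assay, at which 3 of the 4 values shown sit. Steps between two limits cannot be read.

The ring nitrogen and the place of the chlorine change together in compound 4, and this step does not separate them. On these data alone, how a plain phenyl or an amine would read on this carbonyl carbon remains open.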